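A New Group on the Amide of Compound 1

The source may hold more compounds than are shown below. What is called first, only, known or untested is meant among the compounds shown, and "the series" means these compounds.

In a functional assay on HT-29 cells (Homo sapiens) for cytotoxicity, read by MTT assay, with a stated time of 72 h (a higher number here means a weaker inhibitor, a lower number a stronger inhibitor), compound 1 `O=C(CN1CCN(c2nnc(Cc3ccncc3)c3ccccc23)CC1)Nc1ccc(Br)cc1` gives 1990 nM and holds the lowest of three numbers. Compound 2 `O=C(CN1CCN(c2nnc(Cc3ccccc3)c3ccccc23)CC1)Nc1ccc(F)c(C(F)(F)F)c1` gives 4590 nM and compound 3 `O=C(CN1CCN(c2nnc(Cc3ccccc3)c3ccccc23)CC1)Nc1ccc(Br)cc1` gives 60200 nM on the same read-out. Compound 4 `O=C(CN1CCN(c2nnc(Cc3ccncc3)c3ccccc23)CC1)Nc1c(F)cccc1F` differs from compound 1 in one place only: 2,6-difluorophenyl in place of 4-bromophenyl on an amide-type nitrogen so that 2,6-difluorophenyl stands in place of 4-bromophenyl on an amide-type nitrogen.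

The closest measured step is a 13-fold higher number from compound 2 to compound 3 (1.12 log units; beyond the scatter) and it is large. It too is a change on the amide-type nitrogen, so a new group there can shift the number well beyond the scatter. It was seen with phenyl rather than pyridin-4-yl on the saturated chain carbon, however, and 2,6-difluorophenyl has no measurement of its own. The other step, a 30-fold higher number from compound 1 to compound 3 (1.48 log units; beyond the scatter) is also large, but it concerns a change that compound 4 does not make, so it gives no direction here. A moderate rise is expected because compound 1 at 1990 nM stands lowest of the three. The estimate means a 2.3-fold higher number from compound 1 to compound 4 (0.35 log units; beyond the scatter) as the expected step, with a wide margin on either side. In this assay compound 4 is estimated at 4500 nM with 900 nM to 22000 nM as the expected range.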

Compound 4, half-maximal inhibitory concentration: 28700 nM
Estimate against measurement, compound 4: 6.4-fold (0.80 log units) below, outside the stated range (above it).
By their numbers in this assay, from the lowest: compound 1; then compound 2; then compound 4; then compound 3.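

Within this assay, the amide-type nitrogen proves just as sensitive with pyridin-4-yl on the saturated chain carbon as it was with phenyl there, for 2,6-difluorophenyl in place of 4-bromophenyl gives a 14-fold higher number from compound 1 to compound 4 (1.16 log units; beyond the scatter). The earlier change at this place also showed that 4-bromophenyl is not always the group with the higher number: it held that side in a 13-fold higher number from compound 2 to compound 3 (1.12 log units; beyond the scatter), but with pyridin-4-yl it now holds the lower side, although the two steps replace it with different groups and so show no true reversal. Nothing measured here accounts for the size of the new step, and no evidence on its cause is available.

This single step changes the halogen and its place on the ring together, so it cannot separate the loss of bromine from the arrival of the two fluorines, and it leaves open how 4-fluoro-3-(trifluoromethyl)phenyl would read with pyridin-4-yl on the chain carbon. Also open, as far as these compounds go, is whether a group of another kind on the amide-type nitrogen, such as a cyclohexyl ring, a longer alkyl chain or a pyridine ring, would keep the number near that of compound 1.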